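A few compounds are considered here, and "the series" means these few. Any claim that something is new, unique, unknown or untested is made for them only; others in the source may bear on it.

Of the compounds shown here, three sharing one core have been tested in an ADME assay on LLC-MK2 cells (Macaca mulatta) for cytotoxicity, read by spectrophotometry and crystal violet staining, with a stated time of 4 days; a lower number here means that less compound is tolerated, a higher number that more compound is tolerated. Compound 1, `CC(C)n1ncc2c(C(=O)Nc3c(F)cc(F)cc3F)cc(-c3cccs3)nc21`, gives only a limit in this assay: > 200000 nM. Compound 2, `CC(C)n1ncc2c(C(=O)Nc3ccccn3)cc(C3CC3)nc21`, gives 25000 nM in this assay. Compound 3, `CC(C)n1ncc2c(C(=O)Nc3ccncn3)cc(-c3ccsc3)nc21`, likewise reaches only a limit, > 200000 nM. Compound 1 therefore stands at the edge of what this assay can read, and it shares that position with compound 3, while compound 2 alone returns a number; this is summed up as the limit of > 200000 nM in this assay, at which 2 of the 3 values shown sit.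

Compound 4, `CC(C)n1ncc2c(C(=O)Nc3ncccn3)cc(-c3cccs3)nc21`, has not yet been measured. Its relation to compound 1 is a single change on the amide-type nitrogen:

pyrimidin-2-yl in place of 2,4,6-trifluorophenyl on an amide-type nitrogen

For the measured compounds named here, since no pair of measured compounds differs in exactly one place, no measured step can guide the size of this change. Compound 3, which also carries a nitrogen-containing six-membered ring on the amide nitrogen, sits at the limit with > 200000 nM, and this suggests that compound 4 may remain at or near the limit as well. The change expected for compound 4 amounts to an at least 1.3-fold lower number from compound 1 to compound 4 (0.12 log units; that floor lies within the scatter), that is, none beyond the scatter or a modest drop. Compound 4 is thus expected to give about 150000 nM in this assay, within a range from 40000 nM to 300000 nM.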

Compound 4, half-maximal cytotoxic concentration: 75000 nM
For compound 4 the middle estimate is 2.0-fold (0.30 log units) above the measured one; measured number inside the range.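

In this assay, the amide-type nitrogen proves to be a position that matters: with the rest of the molecule unchanged, putting pyrimidin-2-yl in place of 2,4,6-trifluorophenyl gives an at least 2.6-fold lower number from compound 1 to compound 4 (0.42 log units; beyond the scatter), and compound 4 returns a real reading rather than a limit. Compound 1 gives > 200000 nM, which is a limit of the assay and not a number. This step is therefore only a floor, and the true drop could be larger, because compound 1 sits at the edge of what the assay can read: the limit of > 200000 nM in this assay, at which 2 of the 4 values shown sit.

The step swaps a ring of carbon carrying three fluorines for a ring with two nitrogens, so the compounds shown cannot separate the loss of the fluorines from the arrival of the ring nitrogens as the source of the lower number. A plain phenyl group on the same nitrogen, with neither fluorine nor ring nitrogen, would be the natural way to pull these two apart, and how it would read remains an open question.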